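From pyridin-3-yl to 4-cyanophenyl on the shared core

This account rests on a few compounds, and the source may have more. Where it says the series, first, only, none or still open, it means among the compounds named here.

- compound 1 `C[C@H](Nc1ncnc2[nH]cnc12)c1nn(-c2cccc(F)c2)c2cc(F)ccc12`: 32300 nM
- compound 2 `C[C@H](Nc1ncnc2[nH]cnc12)c1nn(-c2cccnc2)c2cc(F)ccc12`: 37500 nM

Both values come from a functional assay on HepG2 cells (Homo sapiens) for inhibition, read by sulforhodamine B assay, with a stated time of 72 h; on this read-out higher numbers stand for weaker inhibition and lower numbers for stronger inhibition. Among the compounds with values here, on these numbers compound 2 stands level with compound 1, the only other compound measured, and the gap between them lies within the usual scatter of repeated measurements.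

The compound still to be measured is compound 3 `C[C@H](Nc1ncnc2[nH]cnc12)c1nn(-c2ccc(C#N)cc2)c2cc(F)ccc12`. It keeps the core of compound 2 and carries 4-cyanophenyl in place of pyridin-3-yl on an aromatic nitrogen.

Within the data shown here, one measured step bears on this change, since it altered the group at that same place. It replaced 3-fluorophenyl with pyridin-3-yl and gave a 1.2-fold higher number from compound 1 to compound 2 (0.06 log units; within the scatter), which is within the scatter. Among the measured compounds shown here, a single step is thin evidence, and no measured compound yet carries a nitrile. With that caution, no step beyond the scatter is expected in this assay, and no direction can be favoured.

The estimated change is a 1.2-fold lower number from compound 2 to compound 3 (0.07 log units; within the scatter). Compound 3 is expected at about 32000 nM, with an estimated range of 13000 nM to 70000 nM.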

Compound 3, half-maximal inhibitory concentration: 15100 nM
Compound 3: middle estimate off by 2.1-fold (0.33 log units), on the high side, and the stated range covers the measured number.
By their numbers in this assay, from the lowest: compound 3; then compounds 1 and 2 (each within the scatter of the next).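

In this assay, the group on the aromatic nitrogen now proves able to move the number: the earlier swap between 3-fluorophenyl and pyridin-3-yl stayed within the scatter, but bringing in 4-cyanophenyl gives a 2.5-fold lower number from compound 2 to compound 3 (0.40 log units; beyond the scatter) and also a 2.1-fold lower number from compound 1 to compound 3 (0.33 log units; beyond the scatter), both modest in size. Compound 3 is therefore the most potent of the three in this cell test, and its group is the only one of the three with a triple bond outside aromatic rings, so here a difference in the number goes together with the nitrile, although three compounds are too few to call this a pattern. Nothing measured among these compounds accounts for the shift.

The compounds shown leave open whether the lower number belongs to the nitrile itself or would also appear with other groups on that phenyl ring, such as an amine, a methoxy group or a carboxylic acid. They also leave open whether a step of this size would hold at any other place on the shared core.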